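Rearranging the Amine Group of Compound 3

A few compounds are considered here, and "the series" means these few. Any claim that something is new, unique, unknown or untested is made for them only; others in the source may bear on it.

In a physicochemical assay for solubility, at pH 7.4 (a higher number here means a more soluble compound, a lower number a less soluble compound), compound 1 `C[C@@H]1[C@@H](N(C)C)CN1c1c(F)cc2c(=O)c(C(=O)O)cn(C3CC3)c2c1F` gives 97.1 ug/mL and stands apart from the other two. Compound 2 `C[C@H]1[C@@H](N)CN1c1c(F)cc2c(=O)c(C(=O)O)cn(C3CC3)c2c1F` gives 23.6 ug/mL and compound 3 `CN[C@H]1CN(c2c(F)cc3c(=O)c(C(=O)O)cn(C4CC4)c3c2F)[C@@H]1C` gives 13.1 ug/mL on the same shared core. These two lie within the scatter of each other, with a 1.8-fold lower number from compound 2 to compound 3 (0.26 log units; within the scatter) as the step. Compound 3 thus shares the low end of the range with compound 2, well short of compound 1.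

The change to compound 4 `CN(C)C1CN(c2c(F)cc3c(=O)c(C(=O)O)cn(C4CC4)c3c2F)C1` is a group of 7 heavy atoms (5 carbon, 2 nitrogen; one four-membered non-aromatic ring with 1 hetero atom) in place of a group of 7 heavy atoms (5 carbon, 2 nitrogen; one four-membered non-aromatic ring with 1 hetero atom), on an aromatic carbon and brings in 3-(dimethylamino)azetidin-1-yl on an aromatic carbon. The two compounds have the same atoms, joined differently. Among the measured compounds, only compound 1 also carries a dimethylamino group. Within the data shown here, the steps that bear on the change are a 7.4-fold lower number from compound 1 to compound 3 (0.87 log units; beyond the scatter) with hydrogen in place of methyl on an amine nitrogen, and a 4.1-fold lower number from compound 1 to compound 2 (0.61 log units; beyond the scatter) as well. Both are modest. Among the measured compounds shown here, no measured compound carries the group of compound 4 itself, so these steps, read in reverse, serve only as a guide. What is expected is a 3.8-fold higher number from compound 3 to compound 4 (0.58 log units; beyond the scatter) in this assay and thus a modest rise that stops short of compound 1. For compound 4 the estimated value is 50 ug/mL with an expected range from 16 ug/mL to 150 ug/mL as the likely span.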

Compound 4, solubility: 58 ug/mL
Compound 4: middle estimate off by 1.2-fold (0.06 log units), on the low side; the range from low to high includes it.
By their numbers in this assay, from the lowest: compounds 3 and 2 (each within the scatter of the next); then compounds 4 and 1 (each within the scatter of the next).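

In this assay, rejoining the same atoms as 3-(dimethylamino)azetidin-1-yl on this aromatic carbon, ortho to two fluoro groups, gives a 4.4-fold higher number from compound 3 to compound 4 (0.65 log units; beyond the scatter) and so shows that the arrangement of the group counts here, even with its heavy atoms unchanged and with hydrogen-bond donors going from 1 to 0. Among these compounds, the same group also gives a 2.5-fold higher number from compound 2 to compound 4 (0.39 log units; beyond the scatter) and lifts compound 4 clear of the low pair, a separation that the earlier compounds, with compound 1 alone at the high end, could not show for a group without a ring methyl. Against the remaining neighbour the result is a 1.7-fold lower number from compound 1 to compound 4 (0.22 log units; within the scatter) and no change can be read, so among these four compounds the two that carry a dimethylamino group stand together above the two that do not, with no compound going against this.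

The compounds shown leave open whether a diethylamino group or a morpholine ring on the azetidine would hold this level, or whether a primary amine without the ring methyl would fall back towards compound 2. No measurement given here accounts for any of these differences.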